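A few compounds are considered here, and "the series" means these few. Any claim that something is new, unique, unknown or untested is made for them only; others in the source may bear on it.

Measured so far:
- compound 1 `O=C(Nc1nccs1)c1cccc(Nc2ncc(F)c(Nc3ccc(F)cc3)n2)c1`: > 10000 nM
- compound 2 `O=C(Nc1cccc(Nc2ncc(F)c(Nc3ccc(F)cc3)n2)c1)c1ccncc1`: 5280 nM

In a functional assay on KB cells (Homo sapiens) for antiproliferative activity, read by sulforhodamine B assay, with a stated time of 3 days (a higher number here means a weaker inhibitor of growth, a lower number a stronger inhibitor of growth), compound 1 gives > 10000 nM, which is a limit and not a number. Compound 3 `COc1cc(NC(=O)c2cccc(Nc3ncc(F)c(Nc4ccc(F)cc4)n3)c2)cc(OC)c1` has 3,5-dimethoxyphenyl in place of 1,3-thiazol-2-yl on an amide-type nitrogen. Within the data shown here, the only measured step bearing on this is an at least 1.8-fold lower number from compound 1 to compound 2 (0.27 log units; that floor lies within the scatter), a different replacement, so it gives weak guidance. A modest move to a lower number is therefore expected, and the expected step in this assay is an at least 2.0-fold lower number from compound 1 to compound 3 (0.30 log units; that floor lies within the scatter). For compound 3 the estimated value is 5000 nM, with an expected range of 1500 nM to 15000 nM.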

Compound 3, concentration for 50% growth inhibition: 15500 nM
Compound 3: the middle estimate sits 3.1-fold (0.49 log units) below what was measured; measured number outside the range, above it.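

Among these compounds, compound 1 carries only a limit, so no step from compound 1 to compound 3 can be read: the limit of > 10000 nM in this assay, at which 1 of the 3 values shown sits. Still open, from the compounds shown here alone, is whether 3,5-dimethoxyphenyl or 1,3-thiazol-2-yl on the amide-type nitrogen gives the lower number.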